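Replacing furan-2-yl with iodo in compound 1

The source may hold more compounds than are shown below. What is called first, only, known or untested is meant among the compounds shown, and "the series" means these compounds.

Growth tests on cancer cells give a first, rough picture of how active a compound is. Among the measured compounds shown here, in a functional assay on HeLa S3 cells (Homo sapiens) for antiproliferative activity, read by XTT assay, with a stated time of 72 h (a lower number here means a stronger inhibitor, a higher number a weaker inhibitor), compound 1 `CNc1ncnc2c1c(-c1ccco1)cn2[C@@H]1O[C@H](CO)[C@@H](O)[C@H]1O` gives 5000 nM as the only actual number so far. Compound 2 `Nc1nc2c(c(-c3cc4ccccc4o3)cn2[C@@H]2O[C@H](CO)[C@@H](O)[C@H]2O)c(=O)[nH]1` gives > 20000 nM as its result, which is a limit of the assay and not a number. Compound 1 therefore stands alone, with no exact value to be ranked against. The next compound, compound 3 `CNc1ncnc2c1c(I)cn2[C@@H]1O[C@H](CO)[C@@H](O)[C@H]1O`, keeps the core of compound 1 and alters one group: iodo in place of furan-2-yl on an aromatic carbon is the whole change. A ring thus gives way to a single atom. For the measured compounds named here, no measured step in this assay shows what such a swap does, so the expectation stays cautious: a modest step with no firm direction, quite possibly none beyond the scatter. The estimated step of a 1.3-fold lower number from compound 1 to compound 3 (0.10 log units; within the scatter) is small and leans only slightly toward stronger inhibition. Compound 3 is expected at 4000 nM with an estimated range of 400 nM to 20000 nM around that value.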

Compound 3, half-maximal inhibitory concentration: > 20000 nM
Compound 3: no number, only a limit; the forecaster's own chance of this, stated with the estimate: 30%; middle value at least 5.0-fold (0.69 log units) away from the limit.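

Swapping furan-2-yl for iodo on this aromatic carbon in this assay gives an at least 4.0-fold higher number from compound 1 to compound 3 (0.60 log units; beyond the scatter). Among the compounds shown here, this is the first measured step, and it shows that the group at this place matters: with the core of compound 1 unchanged, the five-membered aromatic ring cannot be replaced by a single iodine atom without a clear loss of growth inhibition. The size of that loss is only a lower bound, since the result for compound 3 is a limit of the assay and not a number, and the same ceiling applies to another compound in this short set: the limit of > 20000 nM in this assay, at which 2 of the 3 values shown sit.

The compounds shown do not reveal whether a ring is what counts here, or whether another group could match or improve on furan-2-yl; a phenyl ring, a thiophene ring, a methyl group or an amine on the same carbon would help separate these possibilities. For the compounds shown here, with compound 1 at 5000 nM still the only exact value, no ranking among exact numbers is possible yet.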